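The source may hold more compounds than are shown below. What is called first, only, known or untested is meant among the compounds shown, and "the series" means these compounds.

Working notes on the series, read in a functional assay on HepG2 cells (Homo sapiens) for inhibition, read by MTT assay, with a stated time of 24 h; on this read-out higher numbers stand for weaker inhibition and lower numbers for stronger inhibition. Compound 1 `CC1(C)[C@H]2CC[C@]1(C)N(Cc1cn(-c3cccc(Cl)c3)nn1)C(=O)C2` gives 60 nM, compound 2 `CC1(C)[C@H]2CC[C@]1(C)N(Cc1cn(-c3ccccc3O)nn1)C(=O)C2` gives 120 nM and compound 3 `Cc1ccccc1-n1cc(CN2C(=O)C[C@@H]3CC[C@@]2(C)C3(C)C)nn1` gives 150 nM. Two steps place that last value: a 1.3-fold higher number from compound 2 to compound 3 (0.10 log units; within the scatter), which separates nothing, and a 2.5-fold higher number from compound 1 to compound 3 (0.40 log units; beyond the scatter), a modest gap. The change under review leads to compound 4 `COc1ccc(-n2cc(CN3C(=O)C[C@@H]4CC[C@@]3(C)C4(C)C)nn2)cc1`, with 4-methoxyphenyl in place of 2-methylphenyl on an aromatic nitrogen. Swaps of the group at this place have so far given a 2.0-fold higher number from compound 1 to compound 2 (0.30 log units; within the scatter) as well as the modest gap. Among the measured compounds shown here, no measured compound carries 4-methoxyphenyl, so no shift beyond the scatter is expected in this assay. The expected step is a 1.4-fold lower number from compound 3 to compound 4 (0.13 log units; within the scatter). Compound 4 is estimated at 110 nM, within a range of 40 nM to 300 nM.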

Compound 4, half-maximal inhibitory concentration: 100 nM
Compound 4: middle estimate off by 1.1-fold (0.04 log units), on the high side; the range from low to high includes it.
By their numbers in this assay, from the lowest: compounds 1, 4, 2 and 3 (each within the scatter of the next, the first and the last beyond it).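

In this assay, 4-methoxyphenyl on the aromatic nitrogen cannot be told apart from any of the three earlier groups: a 1.5-fold lower number from compound 3 to compound 4 (0.18 log units; within the scatter), a 1.2-fold lower number from compound 2 to compound 4 (0.08 log units; within the scatter) and a 1.7-fold higher number from compound 1 to compound 4 (0.22 log units; within the scatter). Compound 4 therefore does not separate from either compound 1 or compound 3, although those two lie beyond the scatter of each other. No data on hand explain these steps.

As far as these compounds go, whether a group such as an amine or a carboxylic acid in place of the substituted phenyl would shift the number beyond the scatter remains open.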